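Chloro in place of hydroxy: an expected step

The source may report more compounds than this note shows. Statements on the series, on what has been measured and on what is new or still open speak of the compounds shown alone.

compound 1 `O=C(COc1cccc2ccccc12)N/N=C/c1cccc(O)c1`: 62.7 ug/mL
compound 2 `O=C(COc1cccc2ccccc12)N/N=C/c1ccccc1O`: 3.57 ug/mL

In an ADME assay on HEL cells (Homo sapiens) for cytotoxicity (on this read-out lower numbers stand for higher toxicity in this test and higher numbers for lower toxicity in this test), compound 2 has the lower of the two numbers, 3.57 ug/mL. Compound 3 `O=C(COc1cccc2ccccc12)N/N=C/c1ccccc1Cl` carries chloro in place of hydroxy on an aromatic carbon. Within the data shown here, one measured step bears on this: an 18-fold lower number from compound 1 to compound 2 (1.24 log units; beyond the scatter), a large step in which 2-hydroxyphenyl replaced 3-hydroxyphenyl. Among the measured compounds shown here, no measured pair swaps hydroxy for chloro, so this guide is loose. For the measured compounds named here, with only that step to go on, a rise of smaller size is expected: a 5.6-fold higher number from compound 2 to compound 3 (0.75 log units; beyond the scatter). In this assay the estimate for compound 3 is 20 ug/mL, with an expected range of 5 ug/mL to 80 ug/mL.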

Compound 3, half-maximal cytotoxic concentration: 62.7 ug/mL
For compound 3 the middle estimate is 3.1-fold (0.50 log units) below the measured one, and the stated range covers the measured number.
By their numbers in this assay, from the lowest: compound 2; then compounds 1 and 3 (each within the scatter of the next).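

In this assay the change from 2-hydroxyphenyl to 2-chlorophenyl gives an 18-fold higher number from compound 2 to compound 3 (1.24 log units; beyond the scatter), so the low number of compound 2 is tied to hydroxy at this place, not to just any group ortho to a large group. The other comparison gives no change at the digits printed from compound 1 to compound 3 (within the scatter), so compound 3 and compound 1 cannot be told apart here. No evidence is available to explain the large step. From the compounds shown here alone, it remains open whether an amine or methoxy at this place would give a low number like hydroxy or a high one like chloro.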